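A Methyl Added to Compound 2

The compounds below may be only part of what the source reports. "The series", "measured", "known", "first", "only" and "open" are said of these compounds alone.

Measured in a functional assay on the whole organism for inhibition, with Mus musculus as the target; on this read-out lower numbers stand for an effect already at smaller amounts and higher numbers for an effect only at larger amounts of compound:
Compound 1 `Cc1ccc(C2CN(C)Cc3c(N)cccc32)cc1`: 1.6 mg/kg
Compound 2 `CCNCC(=O)Nc1cccc2c1CN(C)CC2c1ccccc1`: 47 mg/kg

Compound 2, at 47 mg/kg, holds the higher of the two numbers in this assay, and its gap to compound 1, at 1.6 mg/kg, lies beyond the scatter. Compound 3 `CCNCC(=O)Nc1cccc2c1CN(C)CC2c1ccc(C)cc1` is compound 2 with methyl in place of hydrogen on an aromatic carbon, para to a large group, so that phenyl becomes 4-methylphenyl (methyl in place of hydrogen on an aromatic carbon). Compound 1 also carries 4-methylphenyl and gives 1.6 mg/kg, which points toward a lower number. However, compound 1 differs from compound 2 elsewhere as well, so the data do not isolate the methyl. The expected change is therefore modest, an estimated 2.4-fold lower number from compound 2 to compound 3 (0.37 log units; beyond the scatter). For compound 3 the expected value in this assay is 20 mg/kg, within an estimated range of 6 mg/kg to 60 mg/kg.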

Compound 3, dose for half-maximal effect: about 45 mg/kg
Compound 3: middle estimate off by 2.3-fold (0.35 log units), on the low side; measured number inside the range.
By their numbers in this assay, from the lowest: compound 1; then compounds 3 and 2 (each within the scatter of the next).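

In this assay the change from phenyl to 4-methylphenyl, methyl in place of hydrogen on an aromatic carbon, gives a 1.0-fold lower number from compound 2 to compound 3 (0.02 log units; within the scatter), so at this position the methyl does not separate the two compounds. With 4-methylphenyl present on both sides, the other change, ((ethylamino)methyl)carbonyl in place of hydrogen on a nitrogen on an aromatic ring, comes with a 28-fold higher number from compound 1 to compound 3 (1.45 log units; beyond the scatter), and this single step now shows that the large gap goes with that group and not with the methyl. Nothing in the data explains either result.

Going by these compounds, it remains open whether methyl would count for more on the compound with the free aromatic amine, where the matching phenyl partner is absent from these data. Also open, on these data alone, is how a chlorine or a methoxy group at the same place, or a simple acetyl on that nitrogen, would read.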